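Restoring an aromatic ring on the triazole side chain

The source may report more compounds than this note shows. Statements on the series, on what has been measured and on what is new or still open speak of the compounds shown alone.

Compound 3 `CN(CCNCc1cn(CCCO)nn1)CCNc1ccnc2cc(Cl)ccc12` is the weakest member of this set in a functional assay on HCC827 cells (Homo sapiens) for antiproliferative activity, read by sulforhodamine B assay, with a stated time of 72 h; on this read-out lower numbers stand for stronger inhibition and higher numbers for weaker inhibition: the result for compound 3 is a limit of the assay, > 200000 nM, and not a measured number. Compound 1 `CN(CCNCc1cn(-c2ccccc2Cl)nn1)CCNc1ccnc2cc(Cl)ccc12` gives 12000 nM in this assay, and compound 2 `CN(CCNCc1cn(C(C)(C)C)nn1)CCNc1ccnc2cc(Cl)ccc12` gives 56000 nM. The measured steps all lead away from compound 1: a 4.7-fold higher number from compound 1 to compound 2 (0.67 log units; beyond the scatter), an at least 16-fold higher number from compound 1 to compound 3 (1.22 log units; beyond the scatter) and an at least 3.5-fold higher number from compound 2 to compound 3 (0.55 log units; beyond the scatter). Compound 4 `CN(CCNCc1cn(Cc2nc3ccccc3[nH]2)nn1)CCNc1ccnc2cc(Cl)ccc12` differs from compound 3 by 1H-benzimidazol-2-yl in place of 2-hydroxyethyl on a saturated chain carbon bound to an aromatic nitrogen; cut one bond further out, the change reads 3-hydroxypropyl to (1H-benzimidazol-2-yl)methyl. The step from compound 1 to compound 3 is the one that bears most directly on it, since it removed an aryl ring from the triazole nitrogen and gave the largest loss, while the step from compound 2 to compound 3 shows that even tert-butyl sits well below the limit. Compound 4 is therefore expected to return a measured number, an at least 8.0-fold lower number from compound 3 to compound 4 (0.90 log units; beyond the scatter), and its value in this assay is estimated at 25000 nM, within 6000 nM to 120000 nM.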

Compound 4, half-maximal inhibitory concentration: 164000 nM
Compound 4: the middle estimate sits 6.6-fold (0.82 log units) below what was measured; measured number above the stated range.
By their numbers in this assay, from the lowest: compound 1; then compound 2; then compound 4. At a limit, above all of these: compound 3.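

In this assay, an aromatic ring system on this side chain does not by itself restore activity: (1H-benzimidazol-2-yl)methyl on the aromatic nitrogen gives a 14-fold higher number from compound 1 to compound 4 (1.14 log units; beyond the scatter), and the ringless tert-butyl group also stays ahead, with a 2.9-fold higher number from compound 2 to compound 4 (0.47 log units; beyond the scatter). The comparison with 3-hydroxypropyl gives only a floor, an at least 1.2-fold lower number from compound 3 to compound 4 (0.08 log units; that floor lies within the scatter), so no gain from that change can be claimed. Compound 3 remains a limit of the assay and not a measured number: the limit of > 200000 nM in this assay, at which 1 of the 4 values shown sits.

On these data alone, only 2-chlorophenyl stands at the low end of these values, so it remains open whether a plain phenyl or a benzyl group would behave like it or like (1H-benzimidazol-2-yl)methyl. As far as these compounds go, the effect of a 3-aminopropyl group, or of a carboxylic acid on the chain, also remains open.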